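This account rests on a few compounds, and the source may have more. Where it says the series, first, only, none or still open, it means among the compounds named here.

Measured compounds:
Compound 1 `COc1ncnc2c1c(-c1ccsc1)cn2[C@@H]1O[C@H](CO)[C@@H](O)[C@H]1O` gives 75300 nM in an ADME assay on MRC5 cells (Homo sapiens), read by MTT assay, with a stated time of 72 h; a higher number here means a weaker inhibitor, a lower number a stronger inhibitor.
Compound 2 `CNc1ncnc2c1c(-c1ccsc1)cn2[C@@H]1O[C@H](CO)[C@@H](O)[C@H]1O` gives > 100000 nM in this assay, which is a limit of the assay and not a number.
Compound 3 `COc1ncnc2c1c(-c1cc3ccccc3o1)cn2[C@@H]1O[C@H](CO)[C@@H](O)[C@H]1O` gives 65600 nM in this assay.

The two cores differ by 1-benzofuran-2-yl in place of thiophen-3-yl on an aromatic carbon, and compound 1 and compound 3 sit within the usual scatter of each other: a 1.1-fold lower number from compound 1 to compound 3 (0.06 log units; within the scatter). The change from compound 1 to compound 2 is methylamino in place of methoxy on an aromatic carbon, and it moved the number at least to the limit: an at least 1.3-fold higher number from compound 1 to compound 2 (0.12 log units; that floor lies within the scatter). The reading for compound 2 is one of the values that sits at the limit of > 100000 nM in this assay, at which 1 of the 3 values shown sits.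

Compound 4 `CNc1ncnc2c1c(-c1cc3ccccc3o1)cn2[C@@H]1O[C@H](CO)[C@@H](O)[C@H]1O` is not yet measured. Going by the values given here, it differs from compound 3 by methylamino in place of methoxy on an aromatic carbon, and since the two place descriptions match word for word, this is the same change as the one from compound 1 to compound 2, made in both pairs.

Compound 4 is expected to show a step of about a 1.8-fold higher number from compound 3 to compound 4 (0.26 log units; within the scatter), the same direction as an at least 1.3-fold higher number from compound 1 to compound 2 (0.12 log units; that floor lies within the scatter), because compound 3 stands at 65600 nM, close to compound 1. Compound 4 is therefore estimated at 120000 nM, with a range from 55000 nM to 260000 nM, and a fair chance that only a limit is reported.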

Compound 4, half-maximal inhibitory concentration: 75300 nM
Compound 4: the middle estimate sits 1.6-fold (0.20 log units) above what was measured, and the stated range covers the measured number.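

In this assay, methylamino in place of methoxy on the core of compound 3 gives a 1.1-fold higher number from compound 3 to compound 4 (0.06 log units; within the scatter), and 1-benzofuran-2-yl in place of thiophen-3-yl, read between the two methylamino compounds, gives an at least 1.3-fold lower number from compound 2 to compound 4 (0.12 log units; that floor lies within the scatter). Set beside the same change on the core of compound 1, the methylamino step gives no sign that the core matters, but this does not show that the change carries over with the same size: the same change on two cores in this assay, an at least 1.3-fold higher number (0.12 log units; that floor lies within the scatter) from compound 1 to compound 2 and a 1.1-fold higher number (0.06 log units; within the scatter) from compound 3 to compound 4; the limit leaves it open whether they differ Compound 2 is a limit of the assay and not a number, and the exchange of the two aromatic groups stays just as unresolved: the same change on two cores in this assay, a 1.1-fold lower number (0.06 log units; within the scatter) from compound 1 to compound 3 and an at least 1.3-fold lower number (0.12 log units; that floor lies within the scatter) from compound 2 to compound 4; the limit leaves it open whether they differ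

The compounds shown leave open how far compound 2 truly lies from the other three, and whether either change would give a step beyond the scatter on a further core. They also leave open what other groups would do on the aromatic carbon that carries the methoxy or methylamino, such as an unsubstituted amine, a dimethylamine or a longer chain such as butoxy.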